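A few compounds are considered here, and "the series" means these few. Any claim that something is new, unique, unknown or untested is made for them only; others in the source may bear on it.

This study asks how much of each compound is needed to harm mouse fibroblast cells, measured in a toxicity assay on NIH3T3 cells (Mus musculus) for cytotoxicity, read by resazurin assay; a lower number here means that less compound is needed, a higher number that more compound is needed for the effect. Three compounds share one core and differ only in the group on a saturated chain carbon bound to an aromatic nitrogen.

Compound 1 `COC(=O)c1ccc(NCc2cncn2Cc2cccc(N)c2)cc1-c1ccccc1` carries an aminophenyl group there. In this assay compound 1 gives > 10000 nM, which is a limit of the assay and not a number. Compound 2 `COC(=O)c1ccc(NCc2cncn2Cc2ccc(C(C)(C)C)cc2)cc1-c1ccccc1` carries a tert-butylphenyl group instead. Among the compounds with values here, for compound 2 the result in this assay stands as "not determined" (no result reported), so no single number places it; the only other value shown is the limit of > 10000 nM in this assay, at which 1 of the 2 values shown sits.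

Compound 3 `COC(=O)c1ccc(NCc2cncn2Cc2cccc(C#N)c2)cc1-c1ccccc1` is the one still to be measured. It differs from compound 2 by 3-cyanophenyl in place of 4-(tert-butyl)phenyl on a saturated chain carbon bound to an aromatic nitrogen. With no measured step between any two of these compounds, and with the one shown value sitting at a limit, no shift in this assay beyond the usual scatter is expected in either direction. Compound 3 is therefore expected to fall near 15000 nM, within a range from 5000 nM to 50000 nM, most likely again reported only as a limit.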

Compound 3, half-maximal effective concentration: > 10000 nM
Compound 3 gave a limit, no number; the forecaster's own chance of this, stated with the estimate: 75%; the middle value lies beyond the limit too.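

No new step can be read from compound 1 to compound 3, since each result is a limit of the assay and not a number: the limit of > 10000 nM in this assay, at which 2 of the 3 values shown sit. The compounds shown leave open how much of either compound is needed for an effect in this assay, and whether cyano in place of amino changes that amount at all.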